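Amide-nitrogen substituent series: from compound 2 to compound 3

A few compounds are considered here, and "the series" means these few. Any claim that something is new, unique, unknown or untested is made for them only; others in the source may bear on it.

Measured compounds:
compound 1, `CN(C)CCNC(=O)c1c(O)c2cccnc2n(-c2ccccc2)c1=O`, 18.4%
compound 2, `O=C(NN1CCOCC1)c1c(O)c2cccnc2n(-c2ccccc2)c1=O`, -26.2%

The two measured compounds share one core and differ only in the group on the amide-type nitrogen. In a functional assay on the whole organism for inhibition, with Rattus norvegicus as the target, read by cytopathic effect and paw edema, at a dose of 100 mg/kg by the oral route (on this read-out lower numbers stand for less inhibition and higher numbers for more inhibition at the one dose given (going by the name of the read-out)), compound 1 gives 18.4%, and compound 2 gives -26.2%, the lowest of the two numbers. Among the measured compounds shown here, the one measured step, a number 44.6 percentage points lower from compound 1 to compound 2 (beyond the scatter), is large and lies well beyond the scatter, so the group on this nitrogen clearly moves the read-out.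

Compound 3, `Cc1ccc(NC(=O)c2c(O)c3cccnc3n(-c3ccccc3)c2=O)cc1`, has not been measured. Its change from compound 2 is 4-methylphenyl in place of morpholin-4-yl on an amide-type nitrogen. For the measured compounds named here, no measured step covers this particular exchange; the only step at hand, a number 44.6 percentage points lower from compound 1 to compound 2 (beyond the scatter), shows the size of effect this position can carry but does not give a direction for an aromatic group here. The expectation is therefore wide: a return toward the level of compound 1 is as plausible as no movement beyond the scatter. Compound 3 is estimated at 10%, within -25% to 40%, which would mean an expected step of a number 36.2 percentage points higher from compound 2 to compound 3 (beyond the scatter).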

Compound 3, a percentage reported as inhibition, in the whole organism at one dose (the size of the read-out at that dose, not a potency): 2.2%
Compound 3: the middle estimate sits 7.8 percentage points above what was measured; low and high end bracket the measured number.
By their numbers in this assay, from the lowest: compound 2; then compound 3; then compound 1.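

In this assay, the exchange of morpholin-4-yl for 4-methylphenyl on the amide-type nitrogen gives a number 28.4 percentage points higher from compound 2 to compound 3 (beyond the scatter) and so shows a first upward move at this place, with a six-membered aromatic ring of carbon only entering in place of a non-aromatic ring with hetero atoms. The second comparison, 4-methylphenyl in place of 2-(dimethylamino)ethyl, gives a number 16.2 percentage points lower from compound 1 to compound 3 (beyond the scatter) and places compound 3 between the other two compounds, so the three groups on this nitrogen now give three separate levels of the read-out, with both new steps modest. No measurement at hand accounts for this order of the three groups.

From the compounds shown here alone, whether the methyl of the 4-methylphenyl group contributes to the level of compound 3 stays open, and plain phenyl or 4-methoxyphenyl on the same nitrogen would bear on that. Also open, going by these compounds, is whether the level of compound 1 depends on the terminal dimethylamino group or on the chain that carries it, a question that a longer chain such as 3-(dimethylamino)propyl or a 2-hydroxyethyl group would address.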